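A few compounds are considered here, and "the series" means these few. Any claim that something is new, unique, unknown or untested is made for them only; others in the source may bear on it.

The measured compounds are these:

compound 1, `CCCSc1nc(N/N=C(\C)c2ccc(O)cc2)c2nnn(Cc3ccccc3)c2n1`, giving 21600 nM
compound 2, `C#CCSc1nc(N/N=C/c2c(O)ccc3ccccc23)c2nnn(Cc3ccccc3)c2n1`, giving 8970 nM
compound 3, `CCCSc1nc(N/N=C(\C)c2ccccc2O)c2nnn(Cc3cccc(Cl)c3)c2n1`, giving 39900 nM

All three were tested in a functional assay on MCF7 cells (Homo sapiens) for antiproliferative activity, read by MTT assay, with a stated time of 72 h; a higher number here means a weaker inhibitor, a lower number a stronger inhibitor. Among the three numbers, compound 1 stands second highest. Its nearest neighbour is compound 3, whose number is higher, but by a gap that lies within the usual scatter of repeated measurements, so the two cannot be told apart. Compound 2 sits furthest from compound 1 in this assay , with a lower number, and that gap lies beyond the scatter, so compound 2 is the one of the three whose inhibition is clearly stronger than that of compound 1.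

The step now followed goes from compound 1 to a compound not yet measured, compound 4, `CCCSc1nc(N/N=C(\C)c2ccc(Br)cc2)c2nnn(Cc3ccccc3)c2n1`. The two share their core and differ in one place only: bromo in place of hydroxy on an aromatic carbon. Among the compounds with values here, no pair of measured compounds shows this change or any change at a single site, so nothing in the numbers above tells its direction or size. With the three measured numbers all lying in the same weak region, the expectation for compound 4 in this assay is a step of a 1.1-fold lower number from compound 1 to compound 4 (0.03 log units; within the scatter), that is, none beyond the scatter. Compound 4 is therefore estimated at 20000 nM, with a range from 7000 nM to 60000 nM.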

Compound 4, half-maximal inhibitory concentration: 13000 nM
The estimate for compound 4 lay 1.5-fold (0.19 log units) above the measured number, within the range that was stated.
By their numbers in this assay, from the lowest: compounds 2, 4, 1 and 3 (each within the scatter of the next, the first and the last beyond it).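

In this assay, within the data shown here, the exchange of hydroxy for bromo on the aromatic carbon para to a large group gives a 1.7-fold lower number from compound 1 to compound 4 (0.22 log units; within the scatter), the first change at a single site that can be read, and compound 1 and compound 4 cannot be told apart. The move from 4-hydroxyphenyl to 4-bromophenyl removes the hydrogen-bond donor and the hydrogen-bond acceptor counted for the hydroxy group, and no step beyond the scatter comes with it, so at this position the hydroxy group is not required for activity at this weak level in this cell assay. Nothing available bears on why these two compounds read alike.

The compounds shown leave open whether a quite different group at this position, such as an amine, a carboxylic acid or a longer alkyl chain, would give a step beyond the scatter. They also leave open whether the same exchange of hydroxy for bromo would read the same way on a compound with another sulfur-linked chain or another benzyl group.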